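The compounds below may be only part of what the source reports. "The series", "measured", "known", "first", "only" and "open" are said of these compounds alone.

Within the data shown here, in a physicochemical assay for solubility, at pH 7.4 (a higher number here means a more soluble compound, a lower number a less soluble compound), compound 1 (`CCOC(=O)c1c(-c2cccc(Oc3ccccc3)c2)[nH]c2cc(OC)c(F)cc2c1=O`) gives 4300 nM and stands lowest of the two numbers so far. Compound 2 (`CCOC(=O)c1c(-c2cccc(Cl)c2)[nH]c2cc(OC)c(F)cc2c1=O`) gives 20000 nM as the only other measured point. Compound 3 (`COc1cc2[nH]c(-c3cccc(Oc4ccccc4)c3)c(C(=O)OCCO)c(=O)c2cc1F`) keeps the core of compound 1 and alters only the ester chain (hydroxy in place of hydrogen on a saturated chain carbon, two bonds along the chain from an oxygen next to a carbonyl group), with hydroxy in place of hydrogen on a saturated chain carbon, two bonds along the chain from an oxygen next to a carbonyl group, so that ethyl becomes 2-hydroxyethyl.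

Among the measured compounds shown here, the sole measured step (a 4.7-fold higher number from compound 1 to compound 2 (0.67 log units; beyond the scatter)) is modest and lies beyond the scatter. It changes a different place on the molecule, so it serves only loosely as a gauge of size. For the measured compounds named here, no measured pair touches the ester chain. A modest step toward a higher number in this assay is therefore expected, resting on the structural change alone, and a step within the scatter cannot be excluded. The estimate amounts to an expected step (a 2.1-fold higher number from compound 1 to compound 3 (0.32 log units; beyond the scatter)). For compound 3 the estimated value is 9000 nM (expected range 4000 nM to 25000 nM).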

Compound 3, solubility: 3100 nM
For compound 3 the middle estimate is 2.9-fold (0.46 log units) above the measured one; the whole stated range lies above it.
By their numbers in this assay, from the lowest: compounds 3 and 1 (each within the scatter of the next); then compound 2.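

In this assay the ester chain now has a measured pair: ethyl to 2-hydroxyethyl gives a 1.4-fold lower number from compound 1 to compound 3 (0.14 log units; within the scatter), so this single change cannot be told apart from the scatter. The only step shown beyond the scatter remains a 4.7-fold higher number from compound 1 to compound 2 (0.67 log units; beyond the scatter), and it lies at a different place on the molecule, the chloro in place of phenoxy change. On the pairs shown, then, the read-out has moved with the change on the aromatic carbon and not with hydroxy in place of hydrogen on the saturated chain carbon, although one pair at each place is a narrow basis, and nothing measured here offers an explanation for the result.

From the compounds shown here alone, it remains open whether another end on the ester chain, such as an amine, a carboxylic acid or a longer chain carrying the hydroxy, would give a step beyond the scatter. Among these compounds, it is also open whether 2-hydroxyethyl in place of ethyl would read the same on the chloro compound, compound 2, since the only pair at this place has phenoxy on the aromatic carbon.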